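Morpholinyl amide to chloroanilide on a caffeate ester pair

The compounds below may be only part of what the source reports. "The series", "measured", "known", "first", "only" and "open" are said of these compounds alone.

Two cores carry the same ester-linked amide arm. Compound 2 `COCOc1cc(/C=C/C(=O)OCC(=O)NN2CCOCC2)ccc1OCc1ccccc1` and compound 3 `O=C(COC(=O)/C=C/c1ccc(O)c(O)c1)NN1CCOCC1` hold the morpholin-4-yl amide; the difference between the two cores is not broken down here. In a functional assay on K562 cells (Homo sapiens) for cytotoxicity, read by MTT assay, with a stated time of 72 h (a higher number here means a weaker inhibitor, a lower number a stronger inhibitor), compound 2 gives 32400 nM, and compound 3 gives 56800 nM, the two within the scatter of each other. Compound 1 `COCOc1cc(/C=C/C(=O)OCC(=O)Nc2ccc(Cl)cc2)ccc1OCc1ccccc1` is the chloroanilide of the first core. Compound 1 reaches only a limit, > 200000 nM, as noted in the limit of > 200000 nM in this assay, at which 1 of the 3 values shown sits. The change 4-chlorophenyl in place of morpholin-4-yl on an amide-type nitrogen therefore made an at least 6.1-fold higher number from compound 2 to compound 1 (0.79 log units; beyond the scatter). Compound 4 `O=C(COC(=O)/C=C/c1ccc(O)c(O)c1)Nc1ccc(Cl)cc1` applies the same change, (4-chlorophenyl in place of morpholin-4-yl on an amide-type nitrogen), to the second core. Since compound 3 gives 56800 nM and the change made an at least 6.1-fold higher number from compound 2 to compound 1 (0.79 log units; beyond the scatter), compound 4 is expected to move by a 6.2-fold higher number from compound 3 to compound 4 (0.79 log units; beyond the scatter). The estimate for compound 4 in this assay is 350000 nM, between 150000 nM and 1000000 nM.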

Compound 4, half-maximal inhibitory concentration: 99400 nM
Compound 4: middle estimate off by 3.5-fold (0.55 log units), on the high side, outside the stated range (below it).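

In this assay, 4-chlorophenyl in place of morpholin-4-yl on the core of compound 3 gives a 1.8-fold higher number from compound 3 to compound 4 (0.24 log units; within the scatter). The change does not carry over at one size, although two pairs do not show which feature of the cores sets the gap: the same change on two cores in this assay, an at least 6.1-fold higher number (0.79 log units; beyond the scatter) from compound 2 to compound 1 and a 1.8-fold higher number (0.24 log units; within the scatter) from compound 3 to compound 4, at least 3.5-fold (0.54 log units) apart, beyond the scatter of two such steps

Compound 1 is held at a limit and not a number: the limit of > 200000 nM in this assay, at which 1 of the 4 values shown sits.

Still open, from the compounds shown here alone, is whether either core's step extends to other groups on the amide-type nitrogen, such as piperidin-1-yl or unsubstituted phenyl. Going by these compounds, the cores differ in more than one place, so the part of the core tied to the gap also remains open.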